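Pyridin-3-yl in place of the aryl group of compound 2

This account rests on a few compounds, and the source may have more. Where it says the series, first, only, none or still open, it means among the compounds named here.

In an ADME assay on HepG2 cells (Homo sapiens) for cytotoxicity (a higher number here means that more compound is tolerated, a lower number that less compound is tolerated), compound 1 (`CSc1cccc(N(CC(=O)NC2CCCC2)C(=O)c2cc3ccc(C(F)(F)F)cc3n2C)c1`) gives 6300 nM and compound 2 (`CSc1cccc(N2C(=O)CN(c3ccc(C(F)(F)F)cc3)CC2C(=O)NC2CCCC2)c1`) gives 10000 nM as the measured numbers. These two values lie within the scatter of each other, so compound 2 stands level with compound 1 on the numbers available.

Compound 3 (`CSc1cccc(N2C(=O)CN(c3cccnc3)CC2C(=O)NC2CCCC2)c1`) differs from compound 2 in one place (pyridin-3-yl in place of 4-(trifluoromethyl)phenyl on an amine nitrogen in a ring): pyridin-3-yl in place of 4-(trifluoromethyl)phenyl on an amine nitrogen in a ring. Going by the values given here, no two measured compounds differ in only one place, so the series offers no direct guide to this change. A small move toward a higher number in this assay is expected, about the size of the scatter, with little firm support from the data. The expected change is a 1.5-fold higher number from compound 2 to compound 3 (0.18 log units; within the scatter) in this estimate. For compound 3 the estimated value is 15000 nM with an expected range from 6000 nM to 40000 nM until a measurement is available.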

Compound 3, half-maximal cytotoxic concentration: > 50000 nM
Compound 3 ended at the assay's limit (the forecaster's own chance of this, stated with the estimate: 25%); middle value at least 3.3-fold (0.52 log units) away from the limit.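

Going by these compounds alone, this is the first one-place step, and it shows that the group on the amine nitrogen in a ring matters: in this assay, pyridin-3-yl in place of 4-(trifluoromethyl)phenyl gives an at least 5.0-fold higher number from compound 2 to compound 3 (0.69 log units; beyond the scatter). Compound 3 gives > 50000 nM, which is a limit of the assay and not a number. The step is therefore a lower bound, and its full size stays unknown: the limit of > 50000 nM in this assay, at which 1 of the 3 values shown sits.

The change swaps the ring and removes the trifluoromethyl group in a single step, so the compounds shown cannot separate the two contributions. Unsubstituted phenyl at this position would separate them, and pyridin-2-yl or pyridin-4-yl would show whether the place of the ring nitrogen matters.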